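The source may hold more compounds than are shown below. What is called first, only, known or untested is meant among the compounds shown, and "the series" means these compounds.

Compound 3, `O=C(CCl)N1N=C(c2cc3ccccc3oc2=O)CC1c1ccccc1`, was tested in a functional assay on MGC-803 cells (Homo sapiens) for cytotoxicity, read by MTT assay, with a stated time of 48 h (on this read-out lower numbers stand for stronger inhibition and higher numbers for weaker inhibition), and gave 2020 nM. That is the lowest of the three numbers recorded: compound 2, `COc1ccccc1C1CC(C)=NN1C(=O)CN1CCC(OC)CC1`, gave 9550 nM, and compound 1, `CC1=NN(C(=O)CN2CCN(C(=O)OC(C)(C)C)CC2)C(c2ccccc2O)C1`, gave 17600 nM, both well beyond the scatter from compound 3. Compound 4, `NC(=O)C1CCN(CC(=O)N2N=C(c3cc4ccccc4oc3=O)CC2c2ccccc2)CC1`, differs from compound 3 in one place: 4-carbamoylpiperidin-1-yl in place of chloro on a saturated chain carbon bound to a carbonyl carbon. Within the data shown here, no comparable step exists among the measured compounds, so the effect of this change is open; however, compound 1 and compound 2, which also carry a saturated nitrogen ring on the chain carbon bound to the carbonyl, show weak inhibition: compound 1 gives 17600 nM and compound 2 gives 9550 nM. A modest loss is therefore expected, a 2.5-fold higher number from compound 3 to compound 4 (0.39 log units; beyond the scatter). For compound 4 the expected value is 5000 nM, in the range 1500 nM to 20000 nM.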

Compound 4, half-maximal inhibitory concentration: 21500 nM
Compound 4: middle estimate off by 4.3-fold (0.63 log units), on the low side; the whole stated range lies below it.
By their numbers in this assay, from the lowest: compound 3; then compounds 2, 1 and 4 (each within the scatter of the next, the first and the last beyond it).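

In this assay, putting 4-carbamoylpiperidin-1-yl in place of chloro on the saturated chain carbon bound to a carbonyl carbon produces an 11-fold higher number from compound 3 to compound 4 (1.03 log units; beyond the scatter) with the rest of the structure unchanged. Among these compounds, this is the first direct reading at this position, and it shows that the result depends strongly on the group carried there. Nothing available explains this loss.

On these data alone, whether it follows from losing chloro or from gaining the ring with its carboxamide stays open. A bromo group, a plain piperidin-1-yl or a morpholin-4-yl on the same carbon would separate these two readings.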